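The source may report more compounds than this note shows. Statements on the series, on what has been measured and on what is new or still open speak of the compounds shown alone.

Measured compounds:
- compound 1 `CCC1C(=O)N(C)c2cnc(-n3ccc4cc(F)ccc43)nc2N1c1ccn(C)n1` — in an assay for inhibition of serine/threonine-protein kinase PLK2 (Homo sapiens), read by FRET and Z'-LYTE, with a stated time of 1 h (on this read-out higher numbers stand for weaker inhibition and lower numbers for stronger inhibition), compound 1 gives 1500 nM
- compound 2 `CCCCNS(=O)(=O)c1ccc(Nc2ncc3c(n2)N(c2ccn(C)n2)C(CC)C(=O)N3C)cc1` — in this assay compound 2 gives 191 nM
- compound 3 `CCC1C(=O)N(C)c2cnc(Nc3ccc(S(N)(=O)=O)cc3)nc2N1c1ccn(C)n1` — in this assay compound 3 gives 121 nM

Compound 1 carries the highest number of the three in this assay; compound 2 sits nearest to it and compound 3 furthest, both beyond the scatter. Within the data shown here, the only step between compounds that differ in one place is the one on the sulfonamide, a 1.6-fold lower number from compound 2 to compound 3 (0.20 log units; within the scatter), and it lies within the scatter.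

Compound 4 `CCC1C(=O)N(C)c2cnc(-n3ccc4cc(C(N)=O)ccc43)nc2N1c1ccn(C)n1` differs from compound 1 in one place: carbamoyl in place of fluoro on an aromatic carbon. Among the measured compounds shown here, no measured step touches this fused ring, so the sulfonamide step from compound 2 to compound 3 bears on it only loosely, as a sign that a change in a hydrogen-bond donor or acceptor on a group at the periphery shifted the number little. Compounds 2 and 3, which carry a donor-bearing group, do give lower numbers than compound 1, but their attachment to the core is different, so no firm direction follows.

The expectation for compound 4 is therefore a step in this assay of a 1.9-fold lower number from compound 1 to compound 4 (0.27 log units; within the scatter), a slight move toward a lower number that may not clear the scatter. Compound 4 is estimated at 800 nM, within 250 nM to 2500 nM.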

Compound 4, half-maximal inhibitory concentration: 384 nM
Beside the measured number, compound 4's estimate is 2.1-fold (0.32 log units) above it; measured number inside the range.
By their numbers in this assay, from the lowest: compounds 3, 2 and 4 (each within the scatter of the next, the first and the last beyond it); then compound 1.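

In this assay, carbamoyl in place of fluoro on an aromatic carbon of the fused system gives a 3.9-fold lower number from compound 1 to compound 4 (0.59 log units; beyond the scatter), which shows that the number responds to the group held at this position of the six-membered aromatic ring. The only other one-place step in the series, a 1.6-fold lower number from compound 2 to compound 3 (0.20 log units; within the scatter), lies within the scatter and sits on a sulfonamide nitrogen, so it gave no sign of how this position would respond, and the change from fluoro to carbamoyl is the only one-place change shown that clears the scatter. No measurement shown here separates the contributions of the larger group, the added hydrogen-bond donor and the added hydrogen-bond acceptor to this step.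

With only fluoro and carbamoyl shown at this position, it remains open whether a nitrile, a carboxylic acid, an aminomethyl group or an N-methylcarbamoyl group would lower the number further, match carbamoyl or reverse the step. Among these compounds, no one-place step connects compound 4 with the sulfonamide-bearing compound 2 or compound 3, so the effect of the carbamoyl group on those compounds also remains open.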